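From Cyclopropyl to Isopropyl on an Amine Nitrogen

The source may report more compounds than this note shows. Statements on the series, on what has been measured and on what is new or still open speak of the compounds shown alone.

In an ADME assay on MT4 cells (Homo sapiens) for cytotoxicity, read by MTT assay, with a stated time of 5 days (on this read-out higher numbers stand for lower toxicity in this test and lower numbers for higher toxicity in this test), compound 1 `CCNC(c1ccc(C#N)cc1)c1ccnc(Nc2ccc(C#N)cc2)n1` gives 158000 nM. Within the data shown here, compound 2 `N#Cc1ccc(Nc2nccc(C(NC3CC3)c3ccc(C#N)cc3)n2)cc1` gives 34700 nM, the lower of the two numbers so far, which makes it the more toxic of the pair in this test. Compound 3 `CC(C)NC(c1ccc(C#N)cc1)c1ccnc(Nc2ccc(C#N)cc2)n1` has isopropyl in place of cyclopropyl on an amine nitrogen, and the count is isopropyl in place of cyclopropyl on an amine nitrogen. Among the measured compounds shown here, one measured step bears on this change: a 4.6-fold lower number from compound 1 to compound 2 (0.66 log units; beyond the scatter), with cyclopropyl in place of ethyl at the same nitrogen. Like the ethyl of compound 1 at 158000 nM, isopropyl has no ring, so a partial move back towards that number is expected, although a single step is thin evidence. The expected size and direction are a 2.2-fold higher number from compound 2 to compound 3 (0.33 log units; beyond the scatter). Compound 3 is estimated at 75000 nM in this assay, with an expected range of 30000 nM to 170000 nM.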

Compound 3, half-maximal cytotoxic concentration: 69200 nM
Compound 3: middle estimate off by 1.1-fold (0.03 log units), on the high side; the measured number falls inside the stated range.
By their numbers in this assay, from the lowest: compounds 2 and 3 (each within the scatter of the next); then compound 1.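

In this assay isopropyl in place of cyclopropyl on the amine nitrogen gives a 2.0-fold higher number from compound 2 to compound 3 (0.30 log units; within the scatter) and so the two groups cannot be told apart here. A ring on this nitrogen is therefore not needed for a number in this range, since the ringless isopropyl of compound 3 reads the same as the cyclopropyl of compound 2 within the scatter. Methyl in place of hydrogen on a saturated chain carbon bound to an amine nitrogen and a saturated chain carbon gives a 2.3-fold lower number from compound 1 to compound 3 (0.36 log units; beyond the scatter) and this shows that the ethyl of compound 1 stands apart from both other groups.

As far as these compounds go, whether a tert-butyl or a cyclobutyl on this nitrogen would read like compound 3 or go further remains open. Nothing measured here explains why ethyl differs from the other two groups.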